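Dropping one chloro from a weakly cytotoxic dichlorophenyl amine

The source may report more compounds than this note shows. Statements on the series, on what has been measured and on what is new or still open speak of the compounds shown alone.

Measured so far:
- compound 1, `COc1cccc(/C=C/C(=O)c2sc(Nc3cccc(Cl)c3)nc2C)c1`: > 25000 nM
- compound 2, `COc1cc(/C=C/C(=O)c2sc(Nc3ccc(Cl)c(Cl)c3)nc2C)cc(OC)c1OC`: 19300 nM
- compound 3, `COc1cccc(/C=C/C(=O)c2sc(Nc3ccccc3)nc2C)c1`: > 25000 nM

The three compounds share a core and were tested in a functional assay on PC-3 cells (Homo sapiens) for cytotoxicity, read by MTT assay; on this read-out lower numbers stand for stronger inhibition and higher numbers for weaker inhibition. Compound 2 is the only one that gives an actual number, 19300 nM. For compound 1 the result is only a limit of the assay, > 25000 nM. For compound 3 the result is likewise only a limit, > 25000 nM. For the measured compounds named here, because of the limit of > 25000 nM in this assay, at which 2 of the 3 values shown sit, the one step between measured compounds, a step that the two limits leave unreadable from compound 1 to compound 3, cannot be read in size or direction.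

Compound 4, `COc1cc(/C=C/C(=O)c2sc(Nc3cccc(Cl)c3)nc2C)cc(OC)c1OC`, has not yet been measured. It differs from compound 2 in one place: hydrogen in place of chloro on an aromatic carbon.

Going by the values given here, no measured step bears directly on this change, since the one available comparison, from compound 1 to compound 3, is hidden behind the limit. What can be said is that compound 1, which carries the same (3-chlorophenyl)amino group as compound 4 on a different core, sits at the limit. Compound 4 is therefore expected to be at best as weak as compound 2, most likely at or beyond the limit, an expected step of a 1.6-fold higher number from compound 2 to compound 4 (0.19 log units; within the scatter). The expected value for compound 4 is 30000 nM, within a range from 15000 nM to 80000 nM.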

Compound 4, half-maximal inhibitory concentration: > 25000 nM
Compound 4: a limit, no number; the forecaster's own chance of this, stated with the estimate: 60%; the middle value is on the limit's open side.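

Taking the chloro off the 3,4-dichlorophenyl group to leave 3-chlorophenyl gives the first step at this position that can be read at all in this assay, even if only in part: an at least 1.2-fold higher number from compound 2 to compound 4 (0.11 log units; that floor lies within the scatter). For the compounds shown here, this says more than the earlier compounds could, since it ties the one measured number to a change at a single aromatic carbon, yet the floor of this step lies within the scatter, so it does not show that the chloro matters for cytotoxicity on these cells. The real size of the step stays hidden, and could be small or much larger, because compound 4 gives only a limit, not a number: the limit of > 25000 nM in this assay, at which 3 of the 4 values shown sit.

On these data alone, it remains open whether a bromo or an amino group on this carbon, in place of the chloro, would give a number lower than that of compound 2. Also open is what the 3,4-dichlorophenyl group would give on the core of compound 1, where the amine partners shown so far give only limits.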